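The compounds below may be only part of what the source reports. "The series", "measured", "known", "first", "only" and "open" are said of these compounds alone.

The measured compounds:

Compound 1, `C=CCNC(=S)NS(=O)(=O)c1ccc(-n2nc(C(=O)O)cc2C)cc1`: in a functional assay on the whole organism (blood, strain albino) with Mus musculus as the target, with stated times of 6 days and 4 h, at a dose of 0.4 mmol/kg by the oral route (a lower number here means less inhibition, a higher number more inhibition at the dose given (going by the name of the read-out)), compound 1 gives -6%.
Compound 2, `CCNC(=O)NS(=O)(=O)c1ccc(-n2nc(C)cc2C)cc1`: in this assay compound 2 gives < 1%, which is a limit of the assay rather than a number.
Compound 3, `CCCNC(=S)NS(=O)(=O)c1ccc(-n2nc(C(=O)O)cc2C)cc1`: in this assay compound 3 gives < 1%, again a limit of the assay.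

Compound 3 thus stands at the floor of what this assay reports; (the limit of < 1% in this assay, at which 2 of the 3 values shown sit). Going by the values given here, the only measured step that reaches compound 3 is a step that the limit leaves unreadable from compound 1 to compound 3, and since compound 3 itself is a limit, the size of that step cannot be read. Compound 4, `CCCNC(=S)NS(=O)(=O)c1ccc(-n2nc(C)cc2C)cc1`, differs from compound 3 by methyl in place of carboxy on an aromatic carbon. Among the compounds with values here, no measured step carries exactly this change. The nearest point of comparison is compound 2, which also bears the methyl group and also sits at the limit of this assay, and compound 1, whose value lies within the scatter of no effect. Nothing in these numbers suggests a step beyond the scatter, so compound 4 is expected to give 0% (range -8% to 8%), and the step it implies, a step that the limit leaves unreadable from compound 3 to compound 4, is estimated to be no larger than the scatter, most likely reported again as a limit.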

Compound 4, a percentage reported as inhibition, in the whole organism at one dose (the size of the read-out at that dose, not a potency): < 1%
Compound 4 was reported as a limit; the forecaster's own chance of this, stated with the estimate: 60%; the middle value lies beyond the limit too.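

In this assay compound 4 gives < 1%, which is a limit of the assay. Its steps from compound 3 and from compound 2 therefore cannot be read: the limit of < 1% in this assay, at which 3 of the 4 values shown sit.

The compounds shown leave open whether methyl in place of carboxy, or the change on the sulfonamide nitrogen, alters inhibition at all.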